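The compounds below may be only part of what the source reports. "The series", "measured", "known", "first", "only" and "open" are said of these compounds alone.

Measured so far:
compound 1 `C[C@@H](NC(=O)c1cnc(C#Cc2cccc(F)c2)cn1)C(C)(C)O`: 64.4%
compound 2 `CC(C)[C@H](C)NC(=O)c1ccc(C#Cc2cccc(F)c2)cn1`: 66.7%

In a functional assay on HEK293 cells for positive allosteric modulation of metabotropic glutamate receptor 5 (Rattus norvegicus), read by fluorescence and calcium flux (on this read-out higher numbers stand for larger maximal responses and lower numbers for smaller maximal responses), compound 2 stands at the top of these two numbers, but its gap to compound 1 is within the scatter, so the two cannot be told apart. Compound 3 `CC(C)(O)CCNC(=O)c1ccc(C#Cc2cccc(F)c2)cn1` is not yet measured and differs from compound 2 by 3-hydroxy-3-methylbutyl in place of 1,2-dimethylpropyl on an amide-type nitrogen. Among the measured compounds shown here, no measured pair carries this change, so for this assay a step of modest size is expected, in either direction or none beyond the scatter. The expected step is a number 4.7 percentage points lower from compound 2 to compound 3 (within the scatter). For compound 3 the estimate is 62%, with a range from 45% to 80%.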

Compound 3, largest response reached (reported as efficacy), in percent of the reference or control that the assay uses: 61.9%
For compound 3 the middle estimate is 0.1 percentage points above the measured one, within the range that was stated.
By their numbers in this assay, from the lowest: compounds 3, 1 and 2 (each within the scatter of the next).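

In this assay, putting 3-hydroxy-3-methylbutyl in place of 1,2-dimethylpropyl on the amide-type nitrogen gives a number 4.8 percentage points lower from compound 2 to compound 3 (within the scatter), so this position tolerates the added hydroxy group and the loss of the defined stereocentre without a difference that can be told from the scatter. Among the compounds shown here, this is the first single-place comparison at this nitrogen. No evidence bears on this result. Still open, as far as these compounds go, is whether an amine, a carboxylic acid or a longer chain on this nitrogen would stay within the scatter of compound 2.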